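The compounds below may be only part of what the source reports. "The series", "measured", "known", "first", "only" and "open" are said of these compounds alone.

Compound 1 `COCc1cc(OC)c(-c2cccc3c(N(CC4CCOCC4)CC4CC4)c(C)nn23)c(OC)c1`: 110 mL.min-1.g-1
Compound 2 `CCc1nn2c(-c3c(C)cc(OC)cc3OC)cccc2c1N(CC1CCOCC1)CC1CC1`: 450 mL.min-1.g-1
Compound 3 `CCc1nn2c(-c3c(C)cc(C)cc3OC)cccc2c1N(CC1CC1)CC1CCCO1`: 1230 mL.min-1.g-1

These numbers come from an in vitro ADME assay on microsomes from liver (Homo sapiens) for metabolic stability, with a stated time of 15 min; on this read-out lower numbers stand for slow clearance and higher numbers for fast clearance. Compound 1 has the lowest of the three, and compound 2 and compound 3 both lie beyond the usual scatter from it. Compound 4 `CCc1nn2c(-c3c(OC)cc(COC)cc3OC)cccc2c1N(CC1CCOCC1)CC1CC1` has not been measured. It differs from compound 1 by a single small change: methyl in place of hydrogen on a saturated chain carbon bound to an aromatic carbon, so a methyl on the core becomes an ethyl. Among the measured compounds shown here, no measured pair shows this change alone, so its size cannot be read directly. Compound 1 sits at the low end of the data, and the nearest number above it is compound 2 at 450 mL.min-1.g-1. The expected change is a 1.8-fold higher number from compound 1 to compound 4 (0.26 log units; within the scatter), a modest rise that may stay within the scatter. For compound 4 the estimated value is 200 mL.min-1.g-1, with an expected range of 100 mL.min-1.g-1 to 400 mL.min-1.g-1.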

Compound 4, intrinsic clearance in microsomes: 300 mL.min-1.g-1
The estimate for compound 4 lay 1.5-fold (0.18 log units) below the measured number, within the range that was stated.
By their numbers in this assay, from the lowest: compound 1; then compounds 4 and 2 (each within the scatter of the next); then compound 3.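

In this assay, among the compounds shown here, compound 1 and compound 4 form the first pair that differs in one place, so the change from methyl to ethyl can now be read alone. Adding methyl in place of hydrogen on a saturated chain carbon bound to an aromatic carbon gives a 2.7-fold higher number from compound 1 to compound 4 (0.44 log units; beyond the scatter) in this pair, a modest step. Even this small addition at this place can therefore move the clearance number past the usual scatter.

Going by these compounds, whether a longer chain such as propyl, or a trifluoromethyl, would raise the number further at this place stays open. Nothing measured here explains why this step occurs.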